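Removing the methoxy from a weak dichlorophenyl amide

The source may report more compounds than this note shows. Statements on the series, on what has been measured and on what is new or still open speak of the compounds shown alone.

- compound 1 `COc1ccc(/C=C/C(=O)Nc2cc3c(Nc4ccc(Cl)c(Cl)c4)ncnc3s2)cc1` gives 33 nM in a functional assay on HeLa cells (Homo sapiens) for antiproliferative activity, read by MTT assay, with a stated time of 48 h; a higher number here means a weaker inhibitor, a lower number a stronger inhibitor
- compound 2 `COc1ccc(/C=C/C(=O)Nc2cc3c(Nc4cc(Cl)cc(Cl)c4)ncnc3s2)cc1` gives 43300 nM in this assay

Compound 2 holds the higher of the two numbers and is the weaker inhibitor of the pair. Among the compounds with values here, the only measured step is a 1300-fold higher number from compound 1 to compound 2 (3.12 log units; beyond the scatter) for 3,5-dichlorophenyl in place of 3,4-dichlorophenyl on a nitrogen on an aromatic ring. That large step lies at another place in the structure, so it bears only loosely on what follows.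

Compound 3 `O=C(/C=C/c1ccccc1)Nc1cc2c(Nc3cc(Cl)cc(Cl)c3)ncnc2s1` differs from compound 2 by hydrogen in place of methoxy on an aromatic carbon with hydrogen in place of methoxy on an aromatic carbon. Within the data shown here, no measured step covers this change. A step within the scatter is therefore expected in this assay with no firm direction. The estimated step is a 1.2-fold lower number from compound 2 to compound 3 (0.09 log units; within the scatter) and it remains uncertain. For compound 3 the expected value is 35000 nM with an estimated range from 10000 nM to 100000 nM for this compound.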

Compound 3, half-maximal inhibitory concentration: 4 nM
The estimate for compound 3 lay 8800-fold (3.94 log units) above the measured number; measured number below the stated range.
By their numbers in this assay, from the lowest: compound 3; then compound 1; then compound 2.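

Taking the methoxy off, so that 4-methoxyphenyl becomes phenyl, gives an 11000-fold lower number from compound 2 to compound 3 (4.03 log units; beyond the scatter) in this assay, which shows that this ring carbon, para to a large group, has a very large bearing on the result when 3,5-dichlorophenyl sits on the nitrogen. The earlier step, a 1300-fold higher number from compound 1 to compound 2 (3.12 log units; beyond the scatter), was read only with the methoxy in place, and the new result shows that the weak number of compound 2 is not set by the 3,5-dichlorophenyl group alone. No measurement given here accounts for the size of this step.

Going by these compounds, whether hydrogen in place of methoxy would do the same with 3,4-dichlorophenyl on the nitrogen stays open. So does how a fluorine, a hydroxy or an amine on this ring carbon would compare with hydrogen and methoxy.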